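The compounds below may be only part of what the source reports. "The series", "measured", "known", "first", "only" and "open" are said of these compounds alone.

The measured compounds and their values:

compound 1 `COc1c(N2CCN(C(=O)C3COc4ccccc4O3)CC2)c(F)cc2c(=O)c(C(=O)O)cn(C3CC3)c12`: 119000 nM
compound 2 `CCN(CC)C(=O)C1CCCN(c2c(F)cc3c(=O)c(C(=O)O)cn(C4CC4)c3c2OC)C1`: 136000 nM
compound 3 `COc1c(N2CCN(C(=O)C3COc4ccccc4O3)CC2)c(F)c([N+](=O)[O-])c2c(=O)c(C(=O)O)cn(C3CC3)c12`: 110000 nM

All three were run in an ADME assay on Vero cells (Chlorocebus sabaeus) for cytotoxicity, read by MTT assay, with a stated time of 72 h; a lower number here means a stronger inhibitor, a higher number a weaker inhibitor. In this assay compound 1 gives 119000 nM, compound 3 gives 110000 nM, and compound 2 gives 136000 nM. Compound 1 and compound 3 share a core and differ in a single place: nitro in place of hydrogen on an aromatic carbon. This single change moves the number by a 1.1-fold lower number from compound 1 to compound 3 (0.03 log units; within the scatter). Compound 2 stands on a different core; how the two cores differ is not broken down here. The values of compound 2, compound 1 and compound 3 all lie within the scatter of one another, so no order among the three can be read from them.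

Compound 4 `CCN(CC)C(=O)C1CCCN(c2c(F)c([N+](=O)[O-])c3c(=O)c(C(=O)O)cn(C4CC4)c3c2OC)C1` has not yet been measured. It differs from compound 2 in one place: nitro in place of hydrogen on an aromatic carbon. Within the data shown here, this is the same change as the one from compound 1 to compound 3, made on the core of compound 2, and the surroundings of the place are described in the same words for both pairs. Because a 1.1-fold lower number from compound 1 to compound 3 (0.03 log units; within the scatter) stays within the scatter, the same change on the core of compound 2 is expected to leave the number close to where compound 2 stands. Compound 4 is therefore estimated to give about 125000 nM in this assay, with an expected range from 70000 nM to 220000 nM. Among the measured compounds shown here, the expected step is a 1.1-fold lower number from compound 2 to compound 4 (0.04 log units; within the scatter), resting on the one measured example of this change.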

Compound 4, half-maximal inhibitory concentration: 124000 nM
For compound 4 the middle estimate is 1.0-fold (0.00 log units) above the measured one; low and high end bracket the measured number.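

In this assay the nitro change gives a 1.1-fold lower number from compound 2 to compound 4 (0.04 log units; within the scatter), so on the core of compound 2, as on the core of compound 1, the change leaves the number within the scatter. Set side by side, the two steps do not differ: the same change on two cores in this assay, a 1.1-fold lower number (0.03 log units; within the scatter) from compound 1 to compound 3 and a 1.1-fold lower number (0.04 log units; within the scatter) from compound 2 to compound 4, 1.0-fold (0.01 log units) apart, within the scatter of two such steps This shows that, across these two pairs, the change carries from one core to the other without a readable effect in this cell read-out, but it rests on only two steps, neither of which stands clear of the scatter, so it tests the transfer of a null result and not of a measurable shift, and it says nothing about other cores or other assays.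

The compounds shown leave open whether a different group on the same aromatic carbon, such as an amine or a nitrile, would also stay within the scatter on both cores. They also leave open whether the nitro change would behave the same way on a core carrying an ethoxy group in place of the methoxy group, or a simple amine in place of the large group.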